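Benzyl for cyclohexyl on the saturated chain carbon

The source may hold more compounds than are shown below. What is called first, only, known or untested is meant among the compounds shown, and "the series" means these compounds.

Compound 1 `CS(=O)(=O)Nc1ccc(C(C(=O)NCc2ccc(C(F)(F)F)nc2SC2CCCCC2)C2CCCC2)cc1F`: in an assay on CHO cells for antagonist activity at transient receptor potential cation channel subfamily V member 1 (Homo sapiens), read by FLIPR (a higher number here means a weaker inhibitor, a lower number a stronger inhibitor), compound 1 gives 103 nM.
Compound 2 `CC1CCN(c2nc(C(F)(F)F)ccc2CNC(=O)C(c2ccc(NS(C)(=O)=O)c(F)c2)C2CCCCC2)CC1`: in this assay compound 2 gives 31.1 nM.
Compound 3 `Cc1ccc(C(C(=O)NCc2ccc(C(F)(F)F)nc2SC2CCCCC2)c2ccc(NS(C)(=O)=O)c(F)c2)cc1`: in this assay compound 3 gives 7.5 nM.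

Compound 2 stands second highest of the three numbers; above it lies only compound 1, below it compound 3, both gaps beyond the scatter.

Compound 4 `CC1CCN(c2nc(C(F)(F)F)ccc2CNC(=O)C(Cc2ccccc2)c2ccc(NS(C)(=O)=O)c(F)c2)CC1` differs from compound 2 in one place: benzyl in place of cyclohexyl on a saturated chain carbon bound to an aromatic carbon and a carbonyl carbon.

Among the compounds with values here, one measured step bears on this. In the move a 14-fold lower number from compound 1 to compound 3 (1.14 log units; beyond the scatter) a saturated ring on that same carbon gave way to an aromatic ring, and the number fell markedly. Compound 4 also brings an aromatic ring to that carbon, though as benzyl rather than as a ring bound directly, so the direction is expected to match while the size is expected to be smaller.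

Compound 4 is therefore expected to give 12 nM in this assay, within 4 nM to 35 nM, an estimated step of a 2.6-fold lower number from compound 2 to compound 4 (0.41 log units; beyond the scatter).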

Compound 4, inhibition constant: 65.9 nM
Estimate against measurement, compound 4: 5.5-fold (0.74 log units) below, outside the stated range (above it).
By their numbers in this assay, from the lowest: compound 3; then compound 2; then compounds 4 and 1 (each within the scatter of the next).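

In this assay, benzyl in place of cyclohexyl on the saturated chain carbon bound to an aromatic carbon and a carbonyl carbon gives a 2.1-fold higher number from compound 2 to compound 4 (0.33 log units; beyond the scatter), so bringing an aromatic ring to this carbon does not lower the number in every form. The lower number in a 14-fold lower number from compound 1 to compound 3 (1.14 log units; beyond the scatter) came with 4-methylphenyl replacing cyclopentyl and does not carry over to benzyl replacing cyclohexyl, though these two steps differ in both groups and in the rest of the molecule. No measurement at hand accounts for the opposite directions.

Open, from the compounds shown here alone, is how phenyl or 2-phenylethyl on that carbon would stand against cyclohexyl and benzyl on the core of compound 2. Also open, going by these compounds, is whether 4-methylphenyl would give a lower number on that same core.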